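The source may report more compounds than this note shows. Statements on the series, on what has been measured and on what is new or still open speak of the compounds shown alone.

Measured so far:
compound 1 `c1ccc2c(c1)CCC(CNCCCNC1=NCCN1)O2` — in an assay on isolated protein (Bos taurus) with 5-hydroxytryptamine receptor 1D (Homo sapiens) as the target (a higher number here means a weaker inhibitor, a lower number a stronger inhibitor), compound 1 gives 6.31 nM
compound 2 `c1ccc2c(c1)CCC(CNCCCNC1=NCCCC1)O2` — in this assay compound 2 gives 3.98 nM

Within the data shown here, compound 2 has the lower of the two numbers, but the only step in hand, a 1.6-fold lower number from compound 1 to compound 2 (0.20 log units; within the scatter), is within the scatter, so compound 1 and compound 2 are not separated by these data.

Compound 3 `c1ccc2c(c1)CCC(CNCCCNc1ccncn1)O2` is the next point. The change from compound 2 is a group of 6 heavy atoms (4 carbon, 2 nitrogen; one six-membered aromatic ring with 2 hetero atoms) in place of a group of 6 heavy atoms (5 carbon, 1 nitrogen; one six-membered non-aromatic ring with 1 hetero atom), on an amine nitrogen: a pyrimidin-4-yl, aromatic and with two hydrogen-bond acceptors, takes the place of the non-aromatic ring that carries the double bond outside aromatic rings, on the amine nitrogen whose other neighbour is a saturated chain carbon.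

Among the measured compounds shown here, the one measured step, from compound 1 to compound 2, swaps one non-aromatic ring for another and stayed within the scatter; it does not cover a move to an aromatic ring. For the measured compounds named here, no measured pair tests that move, so the expectation rests on the size of the change alone and is uncertain. The number for compound 3 is expected to rise by a 5.0-fold higher number from compound 2 to compound 3 (0.70 log units; beyond the scatter), beyond the scatter. The estimate for compound 3 in this assay is 20 nM, with a range from 4 nM to 100 nM.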

Compound 3, half-maximal inhibitory concentration: 10 nM
The estimate for compound 3 lay 2.0-fold (0.30 log units) above the measured number; the measured number falls inside the stated range.
By their numbers in this assay, from the lowest: compounds 2, 1 and 3 (each within the scatter of the next, the first and the last beyond it).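

Among these compounds, on the amine nitrogen whose other neighbour is a saturated chain carbon, an aromatic ring now appears for the first time, and in this assay pyrimidin-4-yl in place of the non-aromatic six-membered ring gives the first step to pass the scatter (a 2.5-fold higher number from compound 2 to compound 3 (0.40 log units; beyond the scatter)). The same group is not separated from the five-membered non-aromatic ring of compound 1 (a 1.6-fold higher number from compound 1 to compound 3 (0.20 log units; within the scatter)), so this position accepts pyrimidin-4-yl with only a modest step at most among the three compounds, and only compound 2 and compound 3 are told apart. No measurement at hand accounts for the difference between these rings.

On these data alone, it remains open whether the step from compound 2 to compound 3 follows from the aromatic ring itself or from its ring nitrogens, a question that a phenyl or a pyridin-4-yl on the same amine nitrogen would address. The series also leaves open how far this position tolerates groups without a ring, such as an acetyl, and whether the ranking of these rings survives a longer chain.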